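The source may hold more compounds than are shown below. What is called first, only, known or untested is meant among the compounds shown, and "the series" means these compounds.

Compound 1 `O=C(NCc1ccc(F)cc1)c1nc(NCCO)c2cccnc2c1O`: in a functional assay on HCT-116 cells (Homo sapiens) for cytotoxicity, read by MTT assay, with a stated time of 72 h (on this read-out higher numbers stand for weaker inhibition and lower numbers for stronger inhibition), compound 1 gives "not determined" (no result reported). Compound 2 `Nc1cccc(Nc2c(C(=O)NCc3ccc(F)cc3)nc(Br)c3cccnc23)c1`: in this assay compound 2 is reported only as a limit, > 10000 nM.

For the measured compounds named here, compound 1 therefore stands on no number of its own, and the one further value shown is a limit, (the limit of > 10000 nM in this assay, at which 1 of the 2 values shown sits). Compound 3 `O=CNCCCCCCNc1nc(C(=O)NCc2ccc(F)cc2)c(O)c2ncccc12` differs from compound 1 by 4-(formylamino)butyl in place of hydroxy on a saturated chain carbon, two bonds along the chain from a nitrogen on an aromatic ring. Going by the values given here, no measured step of this kind exists, so the author cannot size the change in this assay from the data and expects no direction beyond the scatter to be set by the change itself. Compound 3 is estimated at 5000 nM, in a range from 500 nM to 50000 nM.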

Compound 3, half-maximal inhibitory concentration: 4000 nM
Compound 3: middle estimate off by 1.3-fold (0.10 log units), on the high side; the range from low to high includes it.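

For the compounds shown here, compound 1 carries no number in this assay, so no step from it to compound 3 can be read. The compounds shown leave open what the (6-(formylamino)hexyl)amino group itself contributes to the value in this assay.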